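A Small Swap on the Shared Core

The source may report more compounds than this note shows. Statements on the series, on what has been measured and on what is new or still open speak of the compounds shown alone.

Measured so far:
compound 1 `O=C1NC(=O)/C(=C/c2ccc(OCCSc3nnc(Cc4ccccc4)[nH]3)cc2)S1`: 19.4%
compound 2 `O=C1NC(=O)/C(=C/c2ccc(OCCSc3nnc(-c4ccccc4[N+](=O)[O-])[nH]3)cc2)S1`: 15.3%

In a functional assay on the whole organism (plasma, strain Wistar) with Rattus norvegicus as the target, with a stated time of 15 days, at a dose of 10 mg/kg by the oral route (on this read-out higher numbers stand for a stronger effect at the one dose given and lower numbers for a weaker effect), compound 2 gives 15.3%. For the measured compounds named here, the only other number, from compound 1, is 19.4%, and the step of a number 4.1 percentage points lower from compound 1 to compound 2 (within the scatter) lies within the scatter, so the two cannot be told apart. Compound 3 `O=C1NC(=O)/C(=C/c2ccc(OCCSc3nnc(-c4ccc(Cl)cc4)[nH]3)cc2)S1` differs from compound 2 by 4-chlorophenyl in place of 2-nitrophenyl on an aromatic carbon. Going by the values given here, the one measured step, a number 4.1 percentage points lower from compound 1 to compound 2 (within the scatter), changed the group at this same position without moving the read-out beyond the scatter, so compound 3 is expected to change by a number 1.7 percentage points higher from compound 2 to compound 3 (within the scatter), nothing beyond the scatter. Compound 3 is therefore estimated at 17%, within 5% to 30%.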

Compound 3, a percentage reported as activity, at one dose (the size of the read-out at that dose, not a potency): 19.6%
The estimate for compound 3 lay 2.6 percentage points below the measured number; the measured number falls inside the stated range.
By their numbers in this assay, from the lowest: compounds 2, 1 and 3 (each within the scatter of the next).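

Putting 4-chlorophenyl in place of 2-nitrophenyl gives a number 4.3 percentage points higher from compound 2 to compound 3 (within the scatter), and putting it in place of benzyl gives a number 0.2 percentage points higher from compound 1 to compound 3 (within the scatter). Benzyl, 2-nitrophenyl and 4-chlorophenyl on this aromatic carbon therefore cannot be told apart in this assay, even though the incoming group has no hydrogen-bond acceptors and the 2-nitrophenyl group has some. Nothing available explains this result.

Still open, as far as these compounds go, is whether a group that is not an aromatic ring, such as an amine or a carboxylic acid, would move the number beyond the scatter at this position.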